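Trading a Hydroxyphenyl Amide for a Thiophene Amide

The source may report more compounds than this note shows. Statements on the series, on what has been measured and on what is new or still open speak of the compounds shown alone.

Of the compounds shown here, three on one shared core have been tested in an assay on CHO cells with metabotropic glutamate receptor 5 (Homo sapiens) as the target; on this read-out higher numbers stand for an effect only at larger amounts of compound and lower numbers for an effect already at smaller amounts. Compound 1 `O=C(Nc1cc(-c2ccccc2)nn1-c1ccccc1)c1ccccc1Cl` gives 2500 nM in this assay. Compound 2 `O=C(Nc1cc(-c2ccccc2)nn1-c1ccccc1)c1cccc(F)c1` gives 20 nM, and the step of a 130-fold lower number from compound 1 to compound 2 (2.10 log units; beyond the scatter) is the largest gain seen here. Compound 3 `O=C(Nc1cc(-c2ccccc2)nn1-c1ccccc1)c1ccccc1O` reaches only the limit of this assay, > 10000 nM. Compound 3 thus stands at the weak end of the numbers shown: both an at least 4.0-fold higher number from compound 1 to compound 3 (0.60 log units; beyond the scatter) and an at least 500-fold higher number from compound 2 to compound 3 (2.69 log units; beyond the scatter) run toward higher numbers, and the limit of > 10000 nM in this assay, at which 1 of the 3 values shown sits, marks where its value sits.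

Compound 4 `O=C(Nc1cc(-c2ccccc2)nn1-c1ccccc1)c1ccsc1` has not yet been measured. It differs from compound 3 by thiophen-3-yl in place of 2-hydroxyphenyl on a carbonyl carbon. Among the measured compounds shown here, no measured step brings in a thiophene, so the steps that bear on this change are the two leading into compound 3, an at least 4.0-fold higher number from compound 1 to compound 3 (0.60 log units; beyond the scatter) and an at least 500-fold higher number from compound 2 to compound 3 (2.69 log units; beyond the scatter), which accompanied the arrival of the hydroxy group now leaving. Removing it is expected to give an at least 33-fold lower number from compound 3 to compound 4 (1.52 log units; beyond the scatter), a step downward and beyond the scatter. Compound 4 is expected to give about 300 nM in this assay, within a range from 30 nM to 5000 nM.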

Compound 4, half-maximal effective concentration: 1800 nM
The estimate for compound 4 lay 6.0-fold (0.78 log units) below the measured number; measured number inside the range.
By their numbers in this assay, from the lowest: compound 2; then compounds 4 and 1 (each within the scatter of the next). At a limit, above all of these: compound 3.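

Thiophen-3-yl on the carbonyl carbon gives a value that can be read as a number, where 2-hydroxyphenyl did not: an at least 5.5-fold lower number from compound 3 to compound 4 (0.74 log units; beyond the scatter) is only a bound, since compound 3 stands at a limit: the limit of > 10000 nM in this assay, at which 1 of the 4 values shown sits. A six-membered aromatic ring of carbon only is therefore not needed at this place for a measurable value, yet the five-membered ring does not reach what 3-fluorophenyl gives, with a 90-fold higher number from compound 2 to compound 4 (1.95 log units; beyond the scatter). Against the 2-chlorophenyl amide the swap makes no real difference, with a 1.4-fold lower number from compound 1 to compound 4 (0.14 log units; within the scatter).

Going by these compounds, it remains open whether any five-membered ring can approach compound 2, for instance a furan or a thiophen-2-yl group. A saturated ring such as cyclohexyl on the same carbonyl carbon would show whether an aromatic ring is needed here at all.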